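Indole for oxazolopyridine on the diaryl ether: expectation

This account rests on a few compounds, and the source may have more. Where it says the series, first, only, none or still open, it means among the compounds named here.

Measured compounds:
compound 1 `Cc1ccc(-c2cccc(Oc3ccc4c(c3)c(=O)ncn4Cc3c(F)cc(F)cc3F)c2C(F)(F)F)cn1` — 4.2
compound 2 `O=c1ncn(Cc2c(F)cc(F)cc2F)c2ccc(Oc3cccc(-c4ccccn4)c3C(F)(F)F)cc12` — "not determined" (no result reported) in a physicochemical assay for lipophilicity, at pH 7.4; a higher number here means a more lipophilic compound, a lower number a more polar compound
compound 3 `O=c1ncn(Cc2c(F)cc(F)cc2F)c2ccc(Oc3ccc(-c4nc5ncccc5o4)cc3)cc12` — "not determined" (no result reported) in this assay

The series shares a quinazolinone core carrying a trifluorobenzyl group and a diaryl ether; the compounds differ in the substituent on the distal aryl ring. In this assay compound 1 gives 4.2. In this assay compound 2 gives "not determined" (no result reported), and compound 3 gives "not determined" (no result reported), so no reference point exists for its own value and only compound 1 offers a measured anchor for the series.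

Compound 4 `O=c1ncn(Cc2c(F)cc(F)cc2F)c2ccc(Oc3ccc(-c4ccc5[nH]ccc5c4)cc3)cc12` is the next compound to be measured. It differs from compound 3 in one place: a group of 9 heavy atoms (8 carbon, 1 nitrogen; one five-membered aromatic ring with 1 hetero atom, one six-membered aromatic ring of carbon only) in place of a group of 9 heavy atoms (6 carbon, 2 nitrogen, 1 oxygen; one five-membered aromatic ring with 2 hetero atoms, one six-membered aromatic ring with 1 hetero atom), on an aromatic carbon. Going by the values given here, no step between measured compounds is available to gauge this change, so the size of the step is judged from the nature of the groups exchanged only. The expectation is that compound 4 lies higher than compound 3 would, by a margin beyond the usual scatter, though without a value for compound 3 this cannot be expressed as a step.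

Taking compound 1 as the only anchor, compound 4 is estimated at 4.5, with a range from 3.9 to 5.1.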

Compound 4, distribution coefficient: 4.4
Compound 4: the middle estimate sits 0.10 log units above what was measured; the range from low to high includes it.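

No step can be read between compound 3 and compound 4: in this assay compound 3 gives "not determined" (no result reported) and compound 4 gives 4.4 as its value. No evidence on hand bears on this result. The compounds shown leave open how far 1H-indol-5-yl moves the read-out relative to the group it replaces.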